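The compounds below may be only part of what the source reports. "The series", "measured", "known", "first", "only" and "open" are said of these compounds alone.

Compound 1 `COc1nc2cccc(C(=O)O)c2n1Cc1ccc(-c2ccccc2-c2noc(O)n2)cc1`: 90%
Compound 2 `CCSc1nc2cccc(C(=O)O)c2n1Cc1ccc(-c2ccccc2-c2noc(O)n2)cc1`: 83%

In a functional assay on the whole organism for inhibition, with Rattus norvegicus as the target, with a stated time of 3 h, at a dose of 1 mg/kg by the oral route (on this read-out higher numbers stand for more inhibition at the one dose given (going by the name of the read-out) and lower numbers for less inhibition), compound 1 gives 90% and compound 2 gives 83%. Compound 2 thus holds the lower of the two numbers, but the step of a number 7 percentage points lower from compound 1 to compound 2 (within the scatter) lies within the scatter, so the two compounds are not distinguished by this read-out. Compound 3 `CCNc1nc2cccc(C(=O)O)c2n1Cc1ccc(-c2ccccc2-c2noc(O)n2)cc1` differs from compound 2 by ethylamino in place of ethylsulfanyl on an aromatic carbon. Among the compounds with values here, the only measured step, a number 7 percentage points lower from compound 1 to compound 2 (within the scatter), concerns the same aromatic carbon and was within the scatter; no measured pair shows an ethylamino group there, so no step bears directly on the change. Within the data shown here, because the one neighbouring exchange at this carbon gave only a number 7 percentage points lower from compound 1 to compound 2 (within the scatter), compound 3 is expected to stay close to compound 2, with a step of a number 1 percentage points lower from compound 2 to compound 3 (within the scatter) in this assay and no clear direction. The estimate for compound 3 is 82%, with a range from 60% to 95%.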

Compound 3, a percentage reported as inhibition, in the whole organism at one dose (the size of the read-out at that dose, not a potency): 25%
Beside the measured number, compound 3's estimate is 57 percentage points above it; measured number outside the range, below it.
By their numbers in this assay, from the lowest: compound 3; then compounds 2 and 1 (each within the scatter of the next).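

The aromatic carbon between two ring nitrogen atoms proved sensitive to its substituent in this assay, which the exchange of methoxy for ethylsulfanyl had not shown: ethylamino in place of ethylsulfanyl gives a number 58 percentage points lower from compound 2 to compound 3 (beyond the scatter) and adds a hydrogen-bond donor that ethylsulfanyl lacks. Ethylamino in place of methoxy gives a number 65 percentage points lower from compound 1 to compound 3 (beyond the scatter) as well, so ethylamino stands apart from both other groups, while those two remain within the scatter of each other. Nothing given here accounts for this large difference.

The compounds shown leave open whether an unsubstituted amine, a methylamino group or a dimethylamino group at this carbon would fall as far as ethylamino. They also leave open whether ethoxy, which keeps the chain of ethylamino but has oxygen in place of nitrogen, would stay with methoxy and ethylsulfanyl.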